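The compounds below may be only part of what the source reports. "The series", "measured", "known", "first", "only" and "open" are said of these compounds alone.

Within the data shown here, compound 1 `O=C(Nc1cccc([N+](=O)[O-])c1)C1CCCN(C(=O)c2cc(C(F)(F)F)cc(C(F)(F)F)c2)C1` is one of two compounds measured in an ADME assay on PC-3 cells (Homo sapiens) for cytotoxicity, read by WST assay, tested at 100 uM (on this read-out lower numbers stand for less inhibition and higher numbers for more inhibition at the one concentration tested (going by the name of the read-out)), where compound 1 gives 9%. Among the measured compounds shown here, compound 2 `CC(=O)c1cccc(NC(=O)C2CCCN(C(=O)c3cc(C(F)(F)F)cc(C(F)(F)F)c3)C2)c1` gives 0% in this assay, and the only step between measured compounds is a number 9 percentage points lower from compound 1 to compound 2 (within the scatter). On these numbers compound 2 stands lowest of the two, with compound 1 its nearest neighbour within the scatter, so no order between them can be claimed. Compound 3 `O=C(Nc1cccc(S(=O)(=O)N2CCCC2)c1)C1CCCN(C(=O)c2cc(C(F)(F)F)cc(C(F)(F)F)c2)C1` is not yet measured. It differs from compound 2 in one place: (pyrrolidin-1-yl)sulfonyl in place of acetyl on an aromatic carbon. For the measured compounds named here, the one measured step concerns a different exchange on the same aromatic carbon and stayed within the scatter, so it gives little guidance beyond showing that both measured compounds sit low. Compound 3 is therefore expected to show no step beyond the scatter, with a number 5 percentage points higher from compound 2 to compound 3 (within the scatter) as the expected change. Compound 3 is estimated at 5%, within 0% to 20%.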

Compound 3, a percentage reported as inhibition, at one concentration (the size of the read-out at that concentration, not a potency): 0%
For compound 3 the middle estimate is 5 percentage points above the measured one; measured number inside the range.
By their numbers in this assay, from the lowest: compounds 2, 3 and 1 (each within the scatter of the next).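

In this assay, putting (pyrrolidin-1-yl)sulfonyl in place of acetyl on this aromatic carbon, a change that brings in a five-membered non-aromatic ring, gives no change at the digits printed from compound 2 to compound 3 (within the scatter). Set against nitro, the same group gives a number 9 percentage points lower from compound 1 to compound 3 (within the scatter), so nitro, acetyl and (pyrrolidin-1-yl)sulfonyl cannot be told apart at this position in these three compounds. This shows that a much bulkier group with a ring can sit here without moving the number beyond the scatter, although no measurement shown offers an explanation for how close these numbers lie.

The compounds leave open whether an amine or a carboxylic acid on this aromatic carbon would read any differently. They also leave open how the number responds when the two trifluoromethyl groups of the shared core give way to chlorine atoms.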